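Replacing the ketone side chain of compound 3 with a small nitrogen-rich group

A few compounds are considered here, and "the series" means these few. Any claim that something is new, unique, unknown or untested is made for them only; others in the source may bear on it.

Measured compounds:
- compound 1, `CC(=O)c1ccc2c(c1)C(n1ccccc1=O)=CC(C)(C)O2`: 7.37
- compound 2, `CCC(=O)c1ccc2c(c1)C(n1ccccc1=O)=CC(C)(C)O2`: 6.63
- compound 3, `CC1(C)C=C(n2ccccc2=O)c2cc(C(=O)c3ccco3)ccc2O1`: 6.49

All three compounds share one core and differ only in the group attached to a carbonyl carbon on the aromatic ring. In a functional assay (aorta) with Rattus norvegicus as the target (a lower number here means a less potent compound, a higher number a more potent compound, by a factor of ten per unit of this negative logarithm), compound 3 gives the lowest of the three numbers, yet its gap to compound 2 is within the scatter, so the two cannot be ranked against each other; only compound 1 stands clearly higher, as the step of a number 0.88 log units lower from compound 1 to compound 3 (beyond the scatter) shows. The step of a number 0.74 log units lower from compound 1 to compound 2 (beyond the scatter) and the step of a number 0.14 log units lower from compound 2 to compound 3 (within the scatter) show that changing the group on the carbonyl carbon shifts the number by a modest amount at most.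

Compound 4, `CC1(C)C=C(n2ccccc2=O)c2cc(C(=N)NO)ccc2O1`, goes further: a group of 4 heavy atoms (1 carbon, 2 nitrogen, 1 oxygen; no ring) in place of a group of 7 heavy atoms (5 carbon, 2 oxygen; one five-membered aromatic ring with 1 hetero atom), on an aromatic carbon. Here the carbonyl itself leaves together with the furan-2-yl ring, and a group with no common name enters. Among the measured compounds shown here, no measured step covers a change of this kind; the steps that vary the carbonyl substituent are the closest guide, and they were modest. The expectation is therefore a step of uncertain direction, estimated as a number 0.19 log units lower from compound 3 to compound 4 (within the scatter). For compound 4 the estimated value in this assay is 6.3, with a range from 5.3 to 7.3.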

Compound 4, logarithm of the reciprocal of the active concentration, log(1/C): 5.99
Beside the measured number, compound 4's estimate is 0.31 log units above it, within the range that was stated.
By their numbers in this assay, from the lowest: compound 4; then compounds 3 and 2 (each within the scatter of the next); then compound 1.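

Compound 4 is the first compound here without a carbonyl on this aromatic carbon, and in this assay it lies clearly under all three ketones, as shown by the step of a number 0.50 log units lower from compound 3 to compound 4 (beyond the scatter) and the step of a number 0.64 log units lower from compound 2 to compound 4 (beyond the scatter) and the step of a number 1.38 log units lower from compound 1 to compound 4 (beyond the scatter) taken together. Among the compounds shown here, that last step is the first large one, whereas changing the group on the carbonyl carbon gave only modest steps. No measurement shown here accounts for this fall.

Going by these compounds, it remains open whether the fall follows from losing the carbonyl or from the particular group that enters. A nitrile, a primary amide or a carboxylic acid on the same aromatic carbon would help separate these two readings.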